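Anilino ring change on the shared core

The source may hold more compounds than are shown below. What is called first, only, known or untested is meant among the compounds shown, and "the series" means these compounds.

Measured compounds in a functional assay on MCF7 cells (Homo sapiens) for inhibition, read by MTT assay, with a stated time of 72 h; on this read-out higher numbers stand for weaker inhibition and lower numbers for stronger inhibition:
compound 1, `COc1ccccc1Nc1nc(SCc2cn(Cc3ccccc3Cl)nn2)nc(-c2ccccc2)c1C#N`, gives 6170 nM.
compound 3, `Cc1ccc(Cn2cc(CSc3nc(Nc4ccccc4Cl)c(C#N)c(-c4ccccc4)n3)nn2)cc1`, gives 34400 nM.
compound 2, `Cc1ccc(Cn2cc(CSc3nc(Nc4ccccc4C)c(C#N)c(-c4ccccc4)n3)nn2)cc1`, gives only a limit, > 64000 nM.

Compound 1 holds the lowest of the two numbers; compound 3 sits higher, beyond the scatter. Within the data shown here, the one measured step, an at least 1.8-fold lower number from compound 2 to compound 3 (0.26 log units; that floor lies within the scatter), rests on a limit of > 64000 nM in this assay, at which 1 of the 3 values shown sits, and concerns a different ring position, so it does not bear directly on compound 4, `Cc1ccc(Nc2nc(SCc3cn(Cc4ccccc4Cl)nn3)nc(-c3ccccc3)c2C#N)cc1`, which differs from compound 1 by 4-methylphenyl in place of 2-methoxyphenyl on a nitrogen on an aromatic ring. Among the measured compounds shown here, no measured pair tests this change; the anilino rings seen so far all carry their group where compound 1 does. A higher number is expected: compound 4 is estimated at 15000 nM (range 5000 nM to 50000 nM), a step of a 2.4-fold higher number from compound 1 to compound 4 (0.39 log units; beyond the scatter).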

Compound 4, half-maximal inhibitory concentration: 9420 nM
Compound 4: middle estimate off by 1.6-fold (0.20 log units), on the high side; low and high end bracket the measured number.
By their numbers in this assay, from the lowest: compounds 1 and 4 (each within the scatter of the next); then compound 3. At a limit, above all of these: compound 2.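

Among these compounds, with the rest of compound 1 held fixed, in this assay the change to 4-methylphenyl gives a 1.5-fold higher number from compound 1 to compound 4 (0.18 log units; within the scatter) and is the first measured step at this ring on the shared core. On this pair, 2-methoxyphenyl can give way to 4-methylphenyl without a step beyond the scatter. No measured evidence shown here accounts for this result.

The pair changes the group and its place on the ring together, so the two effects stay unseparated. Going by these compounds, how an amine or a carboxylic acid on this ring would read remains open.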